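Replacing a benzyl arm with a direct methoxyphenyl ring

The source may hold more compounds than are shown below. What is called first, only, known or untested is meant among the compounds shown, and "the series" means these compounds.

Measured so far:
compound 1, `COc1ccc(-c2nn3cc(-c4cccc(N)c4)nc3s2)cc1OC`: 13000 nM
compound 2, `C=C(Br)C(=O)Nc1cccc(-c2cn3c(-c4ccc(OC)cc4)csc3n2)c1`: 620 nM
compound 3, `C=C(Br)C(=O)Nc1cccc(-c2cn3nc(Cc4ccc(OC)cc4)sc3n2)c1`: 850 nM

All three were tested in a functional assay on FM3A cells (Mus musculus) for inhibition, read by cell counting, with a stated time of 2 days; on this read-out lower numbers stand for stronger inhibition and higher numbers for weaker inhibition. Compound 3 has the second highest of the three numbers. Its nearest neighbour is compound 2, whose number is lower by an amount that stays within the usual scatter, so the two cannot be told apart. Compound 1, which lacks the bromoacrylamide found in compounds 2 and 3, gives a number far higher than compound 3, a gap well beyond the scatter.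

Compound 4, `C=C(Br)C(=O)Nc1cccc(-c2cn3nc(-c4cccc(OC)c4)sc3n2)c1`, is not yet measured. Compared with compound 3, the change is 3-methoxyphenyl in place of 4-methoxybenzyl on an aromatic carbon. Compound 2 already shows that a methoxyphenyl ring attached directly to the core, with the same bromoacrylamide, gives a number close to that of compound 3. Going by the values given here, no measured pair isolates the move of the methoxy group to another ring position. Hence only a small step is expected, within the scatter, with no clear direction.

Compound 4 is therefore expected to give about 700 nM, within a range from 250 nM to 2000 nM. The estimated step of a 1.2-fold lower number from compound 3 to compound 4 (0.08 log units; within the scatter) is expected to be small.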

Compound 4, half-maximal inhibitory concentration: 500 nM
The estimate for compound 4 lay 1.4-fold (0.15 log units) above the measured number; the range from low to high includes it.
By their numbers in this assay, from the lowest: compounds 4, 2 and 3 (each within the scatter of the next); then compound 1.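

In this assay, 3-methoxyphenyl serves about as well as 4-methoxybenzyl on this aromatic carbon: the swap gives a 1.7-fold lower number from compound 3 to compound 4 (0.23 log units; within the scatter), so the two groups cannot be told apart here. Going by these compounds alone, this is the first direct comparison at this position on the shared core, and it suggests that the position accepts at least this change in the aryl arm without a clear shift in the number. Two things change together, though, since the benzyl carbon is lost and the methoxy group moves on the ring, and no measurement offers a reason for the outcome.

A 4-methoxyphenyl or plain phenyl group at this position would help separate those two changes. Going by these compounds, whether an amine, a carboxylic acid or a longer alkyl chain would be accepted here remains open.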